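The compounds below may be only part of what the source reports. "The series", "measured", "known", "first", "only" and "open" are said of these compounds alone.

Measured compounds in the series:
Compound 1 `C/C(=C\COC(=O)NC(C)(C)C)C1=CC(=O)C(C)(C)O1`; in a functional assay on L1210 cells (Mus musculus) for inhibition (on this read-out lower numbers stand for stronger inhibition and higher numbers for weaker inhibition), compound 1 gives 4.1 ug/mL.
Compound 2 `C/C(=C\COC(=O)NC(C)C)C1=CC(=O)C(C)(C)O1`; in this assay compound 2 gives 4.9 ug/mL.

Compound 2 has a single neighbour among the measured compounds, compound 1, and the step between them is small: a 1.2-fold higher number from compound 1 to compound 2 (0.08 log units; within the scatter). On these two numbers compound 2 and compound 1 cannot be told apart.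

The next compound, compound 3 `C=CCNC(=O)OC/C=C(\C)C1=CC(=O)C(C)(C)O1`, is not yet measured. It differs from compound 2 by allyl in place of isopropyl on an amide-type nitrogen. Within the data shown here, the one measured step, a 1.2-fold higher number from compound 1 to compound 2 (0.08 log units; within the scatter), also exchanged one group for another on the same amide-type nitrogen and stayed within the scatter. No measured data speak to a group carrying a double bond at this position. No step beyond the scatter is therefore expected in this assay; the expected step is a 1.0-fold higher number from compound 2 to compound 3 (0.01 log units; within the scatter). Compound 3 is estimated at 5 ug/mL, with a range from 2.5 ug/mL to 10 ug/mL.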

Compound 3, half-maximal inhibitory concentration: 6.2 ug/mL
Compound 3: the middle estimate sits 1.2-fold (0.09 log units) below what was measured, within the range that was stated.
By their numbers in this assay, from the lowest: compounds 1, 2 and 3 (each within the scatter of the next).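

In this assay, among these compounds, the allyl group brings a double bond onto the amide-type nitrogen for the first time, and the change from isopropyl gives a 1.3-fold higher number from compound 2 to compound 3 (0.10 log units; within the scatter), still within the scatter. Allyl in place of tert-butyl gives a 1.5-fold higher number from compound 1 to compound 3 (0.18 log units; within the scatter), also within the scatter, so tert-butyl, isopropyl and allyl on this nitrogen cannot be told apart on these numbers, with or without the double bond. No supporting data are available to explain this result.

Whether any group at this nitrogen can produce a step beyond the scatter remains open, since a benzyl, a phenyl, a longer chain or a chain ending in a hydroxyl or an amine is not among the compounds shown. Also open, as far as these compounds go, is the effect of a second alkyl group replacing the amide hydrogen.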